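This account rests on a few compounds, and the source may have more. Where it says the series, first, only, none or still open, it means among the compounds named here.

The account follows compound 1 `COc1ccc(/C=C/C(=O)CC(C)=O)cc1OC` to compound 4 `COc1ccc(/C=C/C(=O)CC(C)=O)cc1`. In a functional assay on MDA-MB-231 cells (Homo sapiens) for cytotoxicity, read by MTT assay, with a stated time of 72 h (a higher number here means a weaker inhibitor, a lower number a stronger inhibitor), compound 1 gives 43100 nM, the second highest of three numbers. Compound 2 `COc1ccc(/C=C/c2cc(C)n[nH]2)cc1OC` gives 38800 nM and compound 3 `Cc1cc(/C=C/c2ccc(O)cc2)on1` gives 55500 nM. The step of a 1.1-fold lower number from compound 1 to compound 2 (0.05 log units; within the scatter) lies within the scatter. The gap between the numbers of compound 1 and compound 3 also lies within the scatter. Compound 4 differs from compound 1 by hydrogen in place of methoxy on an aromatic carbon. Among the compounds with values here, no measured step removes a methoxy from the aromatic ring; the single measured step alters the chain end instead and stayed within the scatter, so it offers no guide to this change. The writer therefore expects no step beyond the scatter, a 1.0-fold higher number from compound 1 to compound 4 (0.02 log units; within the scatter). Compound 4 is estimated at 45000 nM, within a range from 18000 nM to 110000 nM.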

Compound 4, half-maximal inhibitory concentration: 25000 nM
For compound 4 the middle estimate is 1.8-fold (0.26 log units) above the measured one; measured number inside the range.
By their numbers in this assay, from the lowest: compounds 4, 2, 1 and 3 (each within the scatter of the next, the first and the last beyond it).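

Within the data shown here, the first measured change on the aromatic ring, hydrogen in place of methoxy on an aromatic carbon ortho to a methoxy group, gives a 1.7-fold lower number from compound 1 to compound 4 (0.24 log units; within the scatter) in this assay. This methoxy can therefore go without a step beyond the scatter, so its presence is not shown to matter in this assay. Nothing available explains the result. The compounds shown leave open whether an amine, a fluorine atom or a longer ethoxy chain at this place would move the number beyond the scatter. They also leave open whether the remaining methoxy can be replaced in the same way.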